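The source may report more compounds than this note shows. Statements on the series, on what has been measured and on what is new or still open speak of the compounds shown alone.

Compound 3 `CCCC1Nc2cccc([C@@H]3C[C@H]3CNC(=O)C3CC3)c2O1` gives 0.18 nM in an assay on NIH3T3 cells with melatonin receptor type 1A (Homo sapiens) as the target (a lower number here means a stronger inhibitor, a higher number a weaker inhibitor), the lowest of the three numbers measured. Compound 1 `CCCC(=O)NC[C@@H]1C[C@H]1c1cccc2c1OC(CCC)N2` gives 0.94 nM, and compound 2 `CCCC1Nc2cccc([C@@H]3C[C@H]3CNC(=O)C(C)C)c2O1` gives 4.9 nM. Both measured steps lead to the cyclopropyl of compound 3: a 5.2-fold lower number from compound 1 to compound 3 (0.72 log units; beyond the scatter) and a 27-fold lower number from compound 2 to compound 3 (1.43 log units; beyond the scatter). Compound 4 `CCCC1Nc2cccc([C@@H]3C[C@H]3CNC(=O)NCC)c2O1` carries a different change at the same place: ethylamino in place of cyclopropyl on a carbonyl carbon. Since every change seen so far away from the cyclopropyl raises the number, a move to the ethylamino is expected to do the same, modestly, and compound 4 is expected to give 2.5 nM, between 0.6 nM and 10 nM; the expected step is a 14-fold higher number from compound 3 to compound 4 (1.14 log units; beyond the scatter).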

Compound 4, inhibition constant: 3.5 nM
Compound 4: the middle estimate sits 1.4-fold (0.15 log units) below what was measured; the range from low to high includes it.
By their numbers in this assay, from the lowest: compound 3; then compound 1; then compounds 4 and 2 (each within the scatter of the next).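

The ethylamino brings a nitrogen and a hydrogen-bond donor to the carbonyl carbon, yet it does not match the cyclopropyl in this assay (a 19-fold higher number from compound 3 to compound 4 (1.29 log units; beyond the scatter)), and it sits level with the isopropyl (a 1.4-fold lower number from compound 2 to compound 4 (0.15 log units; within the scatter)). It also falls behind the propyl (a 3.7-fold higher number from compound 1 to compound 4 (0.57 log units; beyond the scatter)), so all three ring-free groups give higher numbers than the cyclopropyl. Nothing measured here explains these differences.

As far as these compounds go, whether another ring, such as cyclobutyl, would keep the low number remains open. So does whether a shorter methylamino or a longer propylamino would improve on the ethylamino.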